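Cyclopentenyl for Imidazolyl on the Chlorophenyl Ring

The source may hold more compounds than are shown below. What is called first, only, known or untested is meant among the compounds shown, and "the series" means these compounds.

Compounds measured so far:
- compound 1, `Cn1nc2c(=O)n(CC3(O)CCN(Cc4ccc(-n5ccnc5)cc4Cl)CC3)cnc2c1-c1ccc(CN)cc1`: 228 nM
- compound 2, `Cn1nc2c(=O)n(CC3(O)CCN(Cc4ccc(-c5ccco5)cc4Cl)CC3)cnc2c1-c1ccc(C(=N)N)cc1`: 87.5 nM

In an assay on isolated protein for inhibition of ubiquitin carboxyl-terminal hydrolase 7 (Homo sapiens), with stated times of 30 min and 2 h (a higher number here means a weaker inhibitor, a lower number a stronger inhibitor), compound 1 gives 228 nM. Among the compounds with values here, of the two numbers available this is the higher one; compound 2 gives 87.5 nM in this assay, a lower number whose gap to compound 1 lies beyond the scatter, though compound 2 differs from compound 1 in more than one place and so offers no single step to learn from.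

Compound 3, `Cn1nc2c(=O)n(CC3(O)CCN(Cc4ccc(C5=CCCC5)cc4Cl)CC3)cnc2c1-c1ccc(CN)cc1`, is not yet measured. It arises from compound 1 by one change: cyclopent-1-en-1-yl in place of 1H-imidazol-1-yl on an aromatic carbon. Within the data shown here, no measured pair shows this exchange on the shared core, so the size of the step rests on the two values alone. Among the measured compounds shown here, since the only comparison at hand is the lower number of compound 2, a modest move toward lower numbers, or none beyond the scatter, is expected. The step from compound 1 to compound 3 is estimated as a 1.4-fold lower number from compound 1 to compound 3 (0.15 log units; within the scatter). Compound 3 is expected to give about 160 nM in this assay, within a range of 50 nM to 500 nM.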

Compound 3, half-maximal inhibitory concentration: 76.9 nM
For compound 3 the middle estimate is 2.1-fold (0.32 log units) above the measured one; measured number inside the range.
By their numbers in this assay, from the lowest: compounds 3 and 2 (each within the scatter of the next); then compound 1.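

Exchanging 1H-imidazol-1-yl for cyclopent-1-en-1-yl on this aromatic carbon, meta to a chloro group, gives a 3.0-fold lower number from compound 1 to compound 3 (0.47 log units; beyond the scatter) in this assay, the first single-place step available in this series. The position therefore tolerates the loss of both ring nitrogens and both hydrogen-bond acceptors of the leaving group: a five-membered ring of carbon only, no longer aromatic, gives the lower number. The compounds offer no evidence on why the number falls.

This one step changes the ring's atoms and its aromatic character together, so it cannot show which of the two accounts for the difference. Also open, as far as these compounds go, is how a saturated cyclopentyl group, a phenyl ring or a pyridine ring would behave at this position on the same core.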